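A few compounds are considered here, and "the series" means these few. Any claim that something is new, unique, unknown or untested is made for them only; others in the source may bear on it.

Three close relatives of one amide have been tested so far. Compound 1 `Cc1ccc(-c2cc(NC(=O)c3cncc(Br)c3)n[nH]2)cc1` gives 17900 nM in a functional assay on WM1361 cells (Homo sapiens) for antiproliferative activity, read by MTT assay, with a stated time of 48 h; a lower number here means a stronger inhibitor, a higher number a weaker inhibitor. Compound 2 `Cc1ccc(-c2cc(NC(=O)c3ccc(Br)nc3)n[nH]2)cc1` gives 18600 nM in this assay, and compound 3 `O=C(Nc1cc(-c2ccc(Br)cc2)[nH]n1)c1cncc(Br)c1` gives 20300 nM in this assay.

Compound 2 differs from compound 1 by 6-bromopyridin-3-yl in place of 5-bromopyridin-3-yl on a carbonyl carbon, and this change made a step of a 1.0-fold higher number from compound 1 to compound 2 (0.02 log units; within the scatter). Compound 3 differs from compound 1 by bromo in place of methyl on an aromatic carbon, a change that gave a 1.1-fold higher number from compound 1 to compound 3 (0.05 log units; within the scatter). All three numbers therefore sit together, none of them set apart from the others.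

Compound 4 `O=C(Nc1cc(-c2ccc(Br)cc2)[nH]n1)c1ccc(Br)nc1` is not yet measured. It differs from compound 3 by 6-bromopyridin-3-yl in place of 5-bromopyridin-3-yl on a carbonyl carbon, which is the same change that leads from compound 1 to compound 2, made on the same place and on a core that differs only by the change just described. Since that earlier step was a 1.0-fold higher number from compound 1 to compound 2 (0.02 log units; within the scatter), the step from compound 3 to compound 4 is expected to be similar in size, about a 1.0-fold lower number from compound 3 to compound 4 (0.01 log units; within the scatter). On that basis compound 4 is estimated to give 20000 nM in this assay, most likely between 10000 nM and 40000 nM.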

Compound 4, half-maximal inhibitory concentration: 20600 nM
Beside the measured number, compound 4's estimate is 1.0-fold (0.01 log units) below it; measured number inside the range.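

In this assay, 6-bromopyridin-3-yl in place of 5-bromopyridin-3-yl on a carbonyl carbon gave a 1.0-fold higher number from compound 3 to compound 4 (0.01 log units; within the scatter), which matches the same change made earlier on the core of compound 1: the same change on two cores in this assay, a 1.0-fold higher number (0.02 log units; within the scatter) from compound 1 to compound 2 and a 1.0-fold higher number (0.01 log units; within the scatter) from compound 3 to compound 4, 1.0-fold (0.01 log units) apart, within the scatter of two such steps. Bromo in place of methyl on an aromatic carbon gave a 1.1-fold higher number from compound 2 to compound 4 (0.04 log units; within the scatter), and this change also looks alike on both cores: the same change on two cores in this assay, a 1.1-fold higher number (0.05 log units; within the scatter) from compound 1 to compound 3 and a 1.1-fold higher number (0.04 log units; within the scatter) from compound 2 to compound 4, 1.0-fold (0.01 log units) apart, within the scatter of two such steps. Going by these compounds alone, these pairs show only that two changes with no step beyond the scatter stayed that way on a second core; they do not show that a change with a clear effect would carry over in the same way, and they do not explain why the numbers stay together.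

Only methyl and bromo appear on the aromatic carbon that varies, so an amine or a carboxylic acid in that place remains an open case. On the carbonyl carbon only the two bromopyridinyl groups appear, which leaves open whether a group without bromine, such as a plain phenyl ring, would give a step beyond the scatter.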